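Trifluoromethyl in Place of Methylsulfanyl on a Shared Core

The compounds below may be only part of what the source reports. "The series", "measured", "known", "first", "only" and "open" are said of these compounds alone.

Compound 1 `N#Cc1cc(C(=O)N2CCc3ccccc32)cc(I)c1O` gives 5300 nM in an assay on tissue (RPTEC cells) for inhibition of solute carrier family 22 member 12 (Homo sapiens), read by scintillation counting, with stated times of 15 min and 2 h; a lower number here means a stronger inhibitor, a higher number a weaker inhibitor.
Compound 2 `CSc1cc(C(=O)N2CCc3ccccc32)cc(C#N)c1O` reaches only a limit of this assay, > 100000 nM.

Compound 2 thus stands at the weak end of the two numbers shown, its value being a limit rather than a number, as described in the limit of > 100000 nM in this assay, at which 1 of the 2 values shown sits. Compound 3 `N#Cc1cc(C(=O)N2CCc3ccccc32)cc(C(F)(F)F)c1O` differs from compound 2 by trifluoromethyl in place of methylsulfanyl on an aromatic carbon. Among the measured compounds shown here, the only measured step touching this position, an at least 18-fold higher number from compound 1 to compound 2 (1.27 log units; beyond the scatter), is large. For the measured compounds named here, no measured step covers the entry of trifluoromethyl, so the direction stays open, though a number inside the measurable range is considered possible. Compound 3 is therefore expected to give about 20000 nM, within a range from 4000 nM to 100000 nM. The estimated step is an at least 5.0-fold lower number from compound 2 to compound 3 (0.69 log units; beyond the scatter).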

Compound 3, half-maximal inhibitory concentration: > 100000 nM
Compound 3: only a limit was reported; the forecaster's own chance of this, stated with the estimate: 35%; middle value at least 5.0-fold (0.69 log units) away from the limit.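

With trifluoromethyl in place of iodo on this aromatic carbon, the result is an at least 18-fold higher number from compound 1 to compound 3 (1.27 log units; beyond the scatter), so a second group besides methylsulfanyl fails to keep the measurable inhibition of compound 1 in this assay. Of the three groups shown at this position, only iodo gives a number. The step between compound 2 and compound 3 cannot be read, and the two groups cannot be ranked, both values being limits: the limit of > 100000 nM in this assay, at which 2 of the 3 values shown sit.

On these data alone, whether a chlorine or bromine atom, an amine or a carboxylic acid at this position would give a number inside the measurable range remains open.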